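Cyclobutyl for Cyclopropyl on the Piperazine Amide

The source may report more compounds than this note shows. Statements on the series, on what has been measured and on what is new or still open speak of the compounds shown alone.

Compound 1, `Cc1nc(N2CCN(C3CCOCC3)CC2)nc2ccc(NC(=O)COc3ccc(Cl)cc3)cc12`: 1%
Compound 2, `Cc1nc(N2CCC(N3CCCC3)CC2)nc2ccc(NC(=O)C(C)Oc3ccc(Cl)cc3)cc12`: 34%
Compound 3, `Cc1nc(N2CCN(C(=O)C3CC3)CC2)nc2ccc(NC(=O)COc3ccc(OC(F)(F)F)cc3)cc12`: 43%

Of the compounds shown here, three built on a shared core have been measured in an ADME assay on microsomes from liver (Mus musculus) for metabolic stability, read by HPLC, with a stated time of 30 min, tested at 10 uM; a lower number here means that less of the compound is left, a higher number that more of the compound is left. In this assay compound 1 gives 1%. Compound 2 gives 34%. Compound 3 gives 43%, the highest number of the three; its gap to compound 2 lies within the usual scatter of repeated measurements, so those two cannot be ranked against each other, while its gap to compound 1 lies well beyond that scatter.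

The next compound, compound 4, `Cc1nc(N2CCN(C(=O)C3CCC3)CC2)nc2ccc(NC(=O)COc3ccc(OC(F)(F)F)cc3)cc12`, is compound 3 with a single alteration: cyclobutyl in place of cyclopropyl on a carbonyl carbon. The rest of the molecule, including the trifluoromethoxy-bearing aryl ether and the amide link to the core, stays untouched. Among the measured compounds shown here, since no pair of measured compounds differs only in this way, there is no measured step to lean on; the change is one carbon in a small ring and would be expected to leave the result roughly where compound 3 sits, with at most a modest drift downward that may not clear the scatter. Compound 4 is therefore estimated at 35% in this assay, within a range of 15% to 55%. That estimate corresponds to a step of a number 8 percentage points lower from compound 3 to compound 4 (within the scatter), which is expected to stay close to or just beyond the scatter.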

Compound 4, percent of the compound remaining in the liver assay: 69%
Beside the measured number, compound 4's estimate is 34 percentage points below it, and the stated range ends below it.
By their numbers in the liver assay, from the lowest: compound 1; then compounds 2 and 3 (each within the scatter of the next); then compound 4.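

In the liver assay, compound 3 gives 43% and compound 4 gives 69%. Among the compounds shown here, in the liver assay, putting cyclobutyl in place of cyclopropyl on the carbonyl carbon gives a number 26 percentage points higher from compound 3 to compound 4 (beyond the scatter), the first measured step at this position, and it shows that this small change to the piperazine amide can move the result by more than the usual scatter. In a physicochemical assay for solubility, in phosphate buffer (a lower number here means a less soluble compound, a higher number a more soluble compound), compound 3 gives 8000 nM and compound 4 gives 4000 nM. In the physicochemical assay, the same change reads as a 2.0-fold lower number from compound 3 to compound 4 (0.30 log units; within the scatter), so no real difference in solubility can be claimed and the gain in the remaining compound comes without a clear solubility cost in this pair. Nothing in the data available here explains why the larger ring gives this result.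

For the compounds shown here, this single pair gives only two ring sizes, so it leaves open whether a cyclopentyl ring would continue the rise, and whether an open-chain group such as isopropyl or tert-butyl, or an oxygen-containing ring such as oxetane, would behave like cyclobutyl. Going by these compounds alone, it also leaves open whether the same swap would give a similar step with a different group on the aryl ether, since trifluoromethoxy is the only one that accompanies this change.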